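The source may hold more compounds than are shown below. What is called first, only, known or untested is meant among the compounds shown, and "the series" means these compounds.

Working notes on the series. Going by the values given here, compound 3 `Cc1cc(NCc2ccccn2)n2ncc(-c3ccco3)c2n1` is the only member with a number in a physicochemical assay for solubility, read by HPLC, using the shake flask method, measured as kinetic solubility, with a stated time of 2 h, at pH 7.4; on this read-out lower numbers stand for lower solubility and higher numbers for higher solubility: compound 3 gives 48800 nM. The other two sit at a limit of the assay the limit of < 5000 nM in this assay, at which 2 of the 3 values shown sit, rather than at a number. Compound 1 `COc1ccc(-c2cnn3c(NCc4ccccn4)cc(C)nc23)cc1` gives only the limit < 5000 nM. Compound 2 `Cc1cc(NCc2ccccn2)n2ncc(-c3cccc(Cl)c3)c2n1` likewise gives only the limit < 5000 nM. The step that the two limits leave unreadable from compound 1 to compound 2 cannot be read, but an at least 9.7-fold higher number from compound 1 to compound 3 (0.98 log units; beyond the scatter) and an at least 9.7-fold higher number from compound 2 to compound 3 (0.98 log units; beyond the scatter) show that furan-2-yl in place of either six-membered group raised the number. Compound 4 `Cc1cc(NCc2ccccn2)n2ncc(-c3cncnc3)c2n1` differs from compound 3 in one place: pyrimidin-5-yl in place of furan-2-yl on an aromatic carbon. Among the compounds with values here, no measured step covers this swap directly; both steps onto furan-2-yl point upward, and the new group is not expected to undo that. Compound 4 is estimated at 60000 nM, between 15000 nM and 200000 nM, an expected step of a 1.2-fold higher number from compound 3 to compound 4 (0.09 log units; within the scatter) within the scatter.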

Compound 4, solubility: 111000 nM
Compound 4: middle estimate off by 1.9-fold (0.27 log units), on the low side; the measured number falls inside the stated range.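

In this assay there is a 2.3-fold higher number from compound 3 to compound 4 (0.36 log units; beyond the scatter) and this shows that a six-membered aromatic ring on this aromatic carbon does not by itself keep the number low. Among the six-membered groups, pyrimidin-5-yl stands apart, with an at least 22-fold higher number from compound 2 to compound 4 (1.34 log units; beyond the scatter) and an at least 22-fold higher number from compound 1 to compound 4 (1.34 log units; beyond the scatter) as the two largest steps in the series. Compound 1 and compound 2 still give limits rather than numbers, so these two steps are bounds: the limit of < 5000 nM in this assay, at which 2 of the 4 values shown sit.

Whether the ring nitrogens of pyrimidin-5-yl matter remains open, as no compound shown carries pyridin-3-yl or unsubstituted phenyl here. On these data alone, how a morpholine or a carboxylic acid on this carbon would read also remains open.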